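Chain shortening from compound 2 to compound 3

The source may hold more compounds than are shown below. What is called first, only, known or untested is meant among the compounds shown, and "the series" means these compounds.

In a functional assay on Hs-578T cells (Homo sapiens) for antiproliferative activity (a higher number here means a weaker inhibitor of growth, a lower number a stronger inhibitor of growth), compound 2 (`COCCCCCCCCCCCCCCC/C=C1\CC(CO)(COC(=O)C(C)(C)C)OC1=O`) stands at 5.45 ug/mL and compound 1 (`COCCCCCCCCCCCCCCC/C=C1/CC(CO)(COC(=O)C(C)(C)C)OC1=O`) at 6.77 ug/mL with no real separation. Among the compounds with values here, the sole measured step (a 1.2-fold lower number from compound 1 to compound 2 (0.09 log units; within the scatter)) lies within the scatter and concerns only the double bond geometry, so it gives no size for a chain change. Compound 3 (`COCCCCCCCCCCC/C=C1\CC(CO)(COC(=O)C(C)(C)C)OC1=O`) carries methoxy in place of 4-methoxybutyl on a saturated chain carbon, ten or more bonds along the chain from a double-bonded chain carbon. Within the data shown here, with no measured chain step, the expected step (a 1.0-fold higher number from compound 2 to compound 3 (0.00 log units; within the scatter)) in this assay is none beyond the scatter. For compound 3 the estimated value is 5.5 ug/mL (expected range 2.5 ug/mL to 14 ug/mL).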

Compound 3, concentration for 50% growth inhibition: 7.34 ug/mL
Beside the measured number, compound 3's estimate is 1.3-fold (0.13 log units) below it; the range from low to high includes it.
By their numbers in this assay, from the lowest: compounds 2, 1 and 3 (each within the scatter of the next).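

Within the data shown here, this is the first measured chain step: methoxy in place of 4-methoxybutyl on a saturated chain carbon, ten or more bonds along the chain from a double-bonded chain carbon, gives a 1.3-fold higher number from compound 2 to compound 3 (0.13 log units; within the scatter) in this assay, so the chain can lose this much with no separation. The earlier pair spoke only to double bond geometry. Nothing at hand gives a cause for this result.

Still open, going by these compounds, is whether a much shorter chain would hold this level, or an amine or a carboxylic acid in place of methoxy.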